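The source may report more compounds than this note shows. Statements on the series, on what has been measured and on what is new or still open speak of the compounds shown alone.

Measured compounds:
compound 1 `Cn1c(=O)c2c(nc(SCCc3ccc(Br)cc3)n2C)n(C)c1=O`, 19 nM
compound 2 `Cn1c(=O)c2c(nc(SCCc3ccc(F)cc3)n2C)n(C)c1=O`, 71 nM
compound 3 `Cc1ccc(CCSc2nc3c(c(=O)n(C)c(=O)n3C)n2C)cc1`, 72 nM

In an assay on microsomes for inhibition of Amine oxidase [flavin-containing] B (Homo sapiens), read by fluorescence and spectrophotometry, with a stated time of 20 min (a higher number here means a weaker inhibitor, a lower number a stronger inhibitor), compound 3 gives 72 nM, the highest of the three numbers; compound 2 sits within the scatter of it, while compound 1 stands apart, with a 3.8-fold higher number from compound 1 to compound 3 (0.58 log units; beyond the scatter). Compound 4 `COc1ccc(CCSc2nc3c(c(=O)n(C)c(=O)n3C)n2C)cc1` is not yet measured; it differs from compound 3 by methoxy in place of methyl on an aromatic carbon. Going by the values given here, the steps that bear on this change the same aromatic position: a 3.7-fold higher number from compound 1 to compound 2 (0.57 log units; beyond the scatter), a 3.8-fold higher number from compound 1 to compound 3 (0.58 log units; beyond the scatter) and a 1.0-fold higher number from compound 2 to compound 3 (0.01 log units; within the scatter). Exchanging small groups at this position moved the numbers only modestly, and fluoro against methyl made no difference beyond the scatter, so for methoxy a modest step at most is expected, more likely toward a higher number than a lower one. Compound 4 is therefore estimated at 90 nM, within a range of 35 nM to 250 nM. This expectation amounts to a 1.3-fold higher number from compound 3 to compound 4 (0.10 log units; within the scatter).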

Compound 4, half-maximal inhibitory concentration: 23 nM
Compound 4: middle estimate off by 3.9-fold (0.59 log units), on the high side; measured number outside the range, below it.
By their numbers in this assay, from the lowest: compounds 1 and 4 (each within the scatter of the next); then compounds 2 and 3 (each within the scatter of the next).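

In this assay the change to 4-methoxyphenyl shows that this position can separate groups in a way the fluoro and methyl pair did not, with a 3.1-fold lower number from compound 3 to compound 4 (0.50 log units; beyond the scatter) and a 3.1-fold lower number from compound 2 to compound 4 (0.49 log units; beyond the scatter) in this series. The step of a 1.2-fold higher number from compound 1 to compound 4 (0.08 log units; within the scatter) lies within the scatter, so methoxy matches bromo here, and the four groups fall into two levels. Going by these compounds, whether an amine, a hydroxyl or a longer alkoxy chain here would join methoxy and bromo or fluoro and methyl stays open. No measurement shown explains why these groups pair up as they do.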